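The compounds below may be only part of what the source reports. "The series", "measured", "known", "first", "only" and "open" are said of these compounds alone.

Compound 1, `CCCC(=O)C1=C(C)NC(=O)NC1c1cccs1`, in an assay on membranes from CHO cells for displacement of a labelled ligand from adenosine receptor A1 (Homo sapiens), read by scintillation counting, with a stated time of 60 min, tested at 1 uM (on this read-out lower numbers stand for less inhibition and higher numbers for more inhibition at the one concentration tested (going by the name of the read-out)), gives 2%. Compound 2, `CCCC(=O)C1=C(C)NC(=O)NC1c1ccsc1`, gives 6%.

Within the data shown here, compound 2 stands within the scatter of compound 1; the one measured step, a number 4 percentage points higher from compound 1 to compound 2 (within the scatter), does not separate the two. Compound 3, `CC1=C(C(=O)SC(C)C)C(c2ccsc2)NC(=O)N1`, differs from compound 2 as follows: isopropylsulfanyl in place of propyl on a carbonyl carbon. Among the measured compounds shown here, no measured step touches this carbonyl carbon, so nothing measured bears directly on the change. With both known values near the floor of this assay, compound 3 is expected to stay there, a step of no change at the digits printed from compound 2 to compound 3 (within the scatter). Compound 3 is estimated at 6%, within -5% to 20%.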

Compound 3, a percentage reported as inhibition, at one concentration (the size of the read-out at that concentration, not a potency): 24%
Beside the measured number, compound 3's estimate is 18 percentage points below it; the measured number lies above the stated range.
By their numbers in this assay, from the lowest: compounds 1 and 2 (each within the scatter of the next); then compound 3.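

In this assay, isopropylsulfanyl in place of propyl on the carbonyl carbon gives a number 18 percentage points higher from compound 2 to compound 3 (beyond the scatter) and is the first change shown to lift the number clear of the scatter. The thiophene change on the saturated ring carbon, a number 4 percentage points higher from compound 1 to compound 2 (within the scatter), did not do so, which marks the carbonyl carbon as the place where a change has so far registered. Nothing available accounts for the rise.

Going by these compounds, whether the sulfur or the branched chain carries the rise remains open. So does how an isopropyl ketone, an isopropyl ester or an amine on this carbonyl carbon would compare.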